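Five-membered aromatic ring replacing the pyridyl on the shared core

A few compounds are considered here, and "the series" means these few. Any claim that something is new, unique, unknown or untested is made for them only; others in the source may bear on it.

Compound 3 `Cc1ncccc1-c1ccc(-c2nnc(N(C)Cc3ccc4nccn4c3)o2)cc1` gives 6310 nM in an assay on isolated protein for inhibition of tyrosine-protein kinase receptor UFO (Homo sapiens), read by LC-MS (on this read-out higher numbers stand for weaker inhibition and lower numbers for stronger inhibition), the second highest of the three numbers measured. Compound 1 `CN(Cc1ccc2nccn2c1)c1nnc(-c2ccc(C3CC3)cc2)o1` gives 20000 nM in this assay, and compound 2 `COc1ccccc1-c1ccc(-c2nnc(N(C)Cc3ccc4nccn4c3)o2)cc1` gives 1580 nM. The steps between them are a 3.2-fold lower number from compound 1 to compound 3 (0.50 log units; beyond the scatter), a 4.0-fold higher number from compound 2 to compound 3 (0.60 log units; beyond the scatter) and a 13-fold lower number from compound 1 to compound 2 (1.10 log units; beyond the scatter); all three vary the same position of the shared core.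

Compound 4 `Cc1noc(C)c1-c1ccc(-c2nnc(N(C)Cc3ccc4nccn4c3)o2)cc1` differs from compound 3 by 3,5-dimethyl-1,2-oxazol-4-yl in place of 2-methylpyridin-3-yl on an aromatic carbon. Within the data shown here, the steps that bear on this change are a 3.2-fold lower number from compound 1 to compound 3 (0.50 log units; beyond the scatter) and a 4.0-fold higher number from compound 2 to compound 3 (0.60 log units; beyond the scatter), both modest, showing that exchanges of the group at this position have so far shifted this assay by modest amounts in either direction. Among the measured compounds shown here, no measured step exchanges a six-membered aromatic ring for a five-membered one at this place, so the direction is uncertain. A small step toward a higher number is expected, a 1.3-fold higher number from compound 3 to compound 4 (0.10 log units; within the scatter), possibly within the scatter. The estimate for compound 4 in this assay is 8000 nM, with a range from 2500 nM to 25000 nM.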

Compound 4, half-maximal inhibitory concentration: 31600 nM
Estimate against measurement, compound 4: 4.0-fold (0.60 log units) below; measured number outside the range, above it.
By their numbers in this assay, from the lowest: compound 2; then compound 3; then compounds 1 and 4 (each within the scatter of the next).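

The change keeps the count of heavy atoms but puts a five-membered aromatic ring with 2 hetero atoms in place of a six-membered one with 1, and this alone gives a 5.0-fold higher number from compound 3 to compound 4 (0.70 log units; beyond the scatter), so the ring at this place matters in this assay even at equal size. The 3,5-dimethyl-1,2-oxazol-4-yl group also gives a 20-fold higher number from compound 2 to compound 4 (1.30 log units; beyond the scatter), the widest gap yet at this position, while a 1.6-fold higher number from compound 1 to compound 4 (0.20 log units; within the scatter) leaves it indistinguishable from cyclopropyl. Nothing available explains the weaker inhibition of compound 4.

As far as these compounds go, whether the loss follows the five-membered ring itself or its two methyl groups stays open; an unsubstituted 1,2-oxazol-4-yl would separate the two. Also open, from the compounds shown here alone, is how an amine or a carboxylic acid on the 2-methoxyphenyl ring would read here.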